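An aroyl group on the ring nitrogen of compound 3

A few compounds are considered here, and "the series" means these few. Any claim that something is new, unique, unknown or untested is made for them only; others in the source may bear on it.

compound 1, `O=C(Nc1cc(C(F)(F)F)cc(C(F)(F)F)c1)C1CCc2ccccc2N1C(=O)c1ccccc1Cl`: 4700 nM in a functional assay on ACHN cells (Homo sapiens) for cytotoxicity, read by sulforhodamine B assay, with a stated time of 72 h; on this read-out lower numbers stand for stronger inhibition of growth and higher numbers for weaker inhibition of growth
compound 2, `CCCC(=O)N1c2ccccc2CCC1C(=O)Nc1ccccc1C(F)(F)F`: reported only as a limit, > 70000 nM
compound 3, `O=C(Nc1ccccc1C(F)(F)F)C1CCc2ccccc2N1`: 57600 nM

Among the numbers given, compound 3 stands highest, with compound 1 nearest. Compound 4, `O=C(Nc1ccccc1C(F)(F)F)C1CCc2ccccc2N1C(=O)c1cccc(Cl)c1`, differs from compound 3 by (3-chlorophenyl)carbonyl in place of hydrogen on a nitrogen on an aromatic ring in a ring. For the measured compounds named here, only one measured step touches that nitrogen: an at least 1.2-fold lower number from compound 2 to compound 3 (0.08 log units; that floor lies within the scatter), which removed a propylcarbonyl, and the value of compound 2 is a limit (the limit of > 70000 nM in this assay, at which 1 of the 3 values shown sits), so the step has only a floor. Compound 1 carries an aroyl group there, but it also differs elsewhere, so its lower number cannot be attributed to the nitrogen alone. The step is therefore expected to be a moderate move toward a lower number, a 3.8-fold lower number from compound 3 to compound 4 (0.58 log units; beyond the scatter). For compound 4 a value of 15000 nM is estimated, between 3000 nM and 70000 nM.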

Compound 4, concentration for 50% growth inhibition: 526 nM
The estimate for compound 4 lay 29-fold (1.46 log units) above the measured number; the measured number lies below the stated range.
By their numbers in this assay, from the lowest: compound 4; then compound 1; then compound 3. At a limit, above all of these: compound 2.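

In this assay, (3-chlorophenyl)carbonyl in place of hydrogen on this nitrogen gives a 110-fold lower number from compound 3 to compound 4 (2.04 log units; beyond the scatter) and so shows, without the other differences carried by compound 1, that this single change lowers the number strongly. The acyl group itself counts: 3-chlorophenyl in place of propyl on the carbonyl carbon gives an at least 130-fold lower number from compound 2 to compound 4 (2.12 log units; beyond the scatter) and so shows that a carbonyl on this nitrogen does not suffice alone. Compound 2 stands only as a limit: the limit of > 70000 nM in this assay, at which 1 of the 4 values shown sits.

Still open, as far as these compounds go, is what a plain phenyl would give, or a methoxy group or an amine in place of the chlorine.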